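Second chloro on the benzyl arm of compound 2

The source may hold more compounds than are shown below. What is called first, only, known or untested is meant among the compounds shown, and "the series" means these compounds.

For the measured compounds named here, compound 2 `O=C(O)Cn1c(SCc2cccc(Cl)c2)nc2ccccc21` stands lowest of the three numbers so far in an assay on HEK293 cells for displacement of a labelled ligand from prostaglandin D2 receptor 2 (Homo sapiens) (a higher number here means a weaker inhibitor, a lower number a stronger inhibitor), at 186 nM. Compound 1 `O=C(O)Cn1c(SCCc2ccccc2)nc2ccccc21`, which carries a phenylethyl chain on the sulfur instead, gives 881 nM, and the step of a 4.7-fold lower number from compound 1 to compound 2 (0.68 log units; beyond the scatter) is beyond the scatter. Compound 3 `COC(=O)c1cccc(CSc2nc3ccccc3n2CC(=O)O)c1` gives 450 nM, and the step of a 2.4-fold higher number from compound 2 to compound 3 (0.38 log units; beyond the scatter) is likewise beyond the scatter, so both neighbours sit clearly above compound 2.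

Compound 4 `O=C(O)Cn1c(SCc2cc(Cl)ccc2Cl)nc2ccccc21` differs from compound 2 in one place: chloro in place of hydrogen on an aromatic carbon, on an aromatic carbon of a six-membered aromatic ring of carbon only, ortho to a large group and para to a chloro group. Going by the values given here, no measured step adds a second chloro to this ring. The nearest guidance is the step from compound 2 to compound 3, which changed the existing chloro and moved the number only modestly, and the step from compound 1 to compound 2, in which introducing the chlorophenyl arm lowered the number. The change in compound 4 is smaller than either, so a small step is expected, if any, and most likely not far beyond the scatter.

Compound 4 is therefore expected to give 150 nM in this assay, within 60 nM to 400 nM, a step of a 1.2-fold lower number from compound 2 to compound 4 (0.09 log units; within the scatter).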

Compound 4, half-maximal inhibitory concentration: 470 nM
Beside the measured number, compound 4's estimate is 3.1-fold (0.50 log units) below it, outside the stated range (above it).
By their numbers in this assay, from the lowest: compound 2; then compounds 3, 4 and 1 (each within the scatter of the next).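

In this assay, chloro in place of hydrogen on the aromatic carbon ortho to a large group and para to a chloro group is not a neutral addition, giving a 2.5-fold higher number from compound 2 to compound 4 (0.40 log units; beyond the scatter) as a step beyond the scatter. The second chloro does not extend the lowering seen in the earlier change of arm (a 4.7-fold lower number from compound 1 to compound 2 (0.68 log units; beyond the scatter)), and compound 2 keeps the lowest number in the series, so this previously unsubstituted carbon responds to the addition of a single heavy atom. The data in hand offer no measurement that accounts for the rise in the number.

The compounds shown do not separate the effect of a chloro at this carbon alone from that of having the two chloro groups together on one ring. A fluoro or a methyl at the same carbon, and a methoxy there with the existing chloro kept in place, would show whether the rise follows any group at this position or is particular to the added chloro.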